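One More Methyl on a Short Alkenyl Chain

A few compounds are considered here, and "the series" means these few. Any claim that something is new, unique, unknown or untested is made for them only; others in the source may bear on it.

- Compound 1 `C=CC(=O)Nc1cccc(Oc2nc(Nc3cccc(C#N)c3)nc3c2CSCC3)c1`: 6860 nM
- Compound 2 `CC/C=C/C(=O)Nc1cccc(Oc2nc(Nc3cccc(C#N)c3)nc3c2CSCC3)c1`: 10100 nM
- Compound 3 `CCC/C=C/C(=O)Nc1cccc(Oc2nc(Nc3cccc(C#N)c3)nc3c2CSCC3)c1`: not yet measured

In a functional assay on A549 cells (Homo sapiens) for antiproliferative activity, read by MTT assay, with a stated time of 72 h (on this read-out higher numbers stand for weaker inhibition and lower numbers for stronger inhibition), compound 2 gives 10100 nM. Only compound 1 stands alongside it, at 6860 nM, and the two lie within the scatter of each other, so neither can be ranked above the other.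

Compound 3 differs from compound 2 in one place: methyl in place of hydrogen on a saturated chain carbon, two bonds along the chain from a double-bonded chain carbon. Seen one bond further out, this change turns but-1-en-1-yl into pent-1-en-1-yl.

Among the compounds with values here, one measured step bears on this change: a 1.5-fold higher number from compound 1 to compound 2 (0.17 log units; within the scatter). There, but-1-en-1-yl replaced vinyl on a carbonyl carbon, in the same part of the molecule. A single small step is thin evidence, but it gives no reason to expect a shift in either direction, so no change beyond the scatter is expected in this assay.

The expected step is a 1.1-fold higher number from compound 2 to compound 3 (0.04 log units; within the scatter).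

For compound 3 the estimate is 11000 nM, with an expected range of 5500 nM to 22000 nM.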

Compound 3, half-maximal inhibitory concentration: 5790 nM
For compound 3 the middle estimate is 1.9-fold (0.28 log units) above the measured one; the range from low to high includes it.
By their numbers in this assay, from the lowest: compounds 3, 1 and 2 (each within the scatter of the next).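

In this assay the added methyl on this saturated chain carbon, which turns but-1-en-1-yl into pent-1-en-1-yl, gives a 1.7-fold lower number from compound 2 to compound 3 (0.24 log units; within the scatter) and so leaves the read-out inside the usual scatter. Comparing the two ends of the series tells the same story: pent-1-en-1-yl in place of vinyl on the carbonyl carbon gives a 1.2-fold lower number from compound 1 to compound 3 (0.07 log units; within the scatter) and thus also stays inside the scatter, so compounds 1, 2 and 3 cannot be ranked, and this group can be lengthened from vinyl to pent-1-en-1-yl with no readable effect on the number. Nothing measured here speaks to what lies behind these numbers.

Whether a longer chain, such as hept-1-en-1-yl, would finally move the number beyond the scatter remains open, since the steps shown so far cover only short chains. On these data alone, it is equally open whether a chain ending in an amine or a carboxylic acid, or one carrying a phenyl ring in place of the alkyl end, would behave like these three or shift the read-out clearly in either direction.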